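This account rests on a few compounds, and the source may have more. Where it says the series, first, only, none or still open, it means among the compounds named here.

Measured so far:
compound 1, `CN(Cc1ccccc1)C(=O)c1nc2ccccc2n1Cc1ccc(Cl)cc1`, > 10000 nM
compound 2, `C#CCN(C)C(=O)c1nc2ccccc2n1Cc1ccc(OC)cc1`, > 10000 nM

Of the compounds shown here, two have been measured in an assay on HEK293 cells for displacement of a labelled ligand from Translocator protein (Homo sapiens), read by scintillation counting, with a stated time of 90 min; a higher number here means a weaker inhibitor, a lower number a stronger inhibitor. Compound 1, with structure `CN(Cc1ccccc1)C(=O)c1nc2ccccc2n1Cc1ccc(Cl)cc1`, gives > 10000 nM, which is a limit of the assay rather than a number. Compound 2, with structure `C#CCN(C)C(=O)c1nc2ccccc2n1Cc1ccc(OC)cc1`, gives > 10000 nM, again a limit of the assay and not a number. Compound 2 therefore stands at the limit of > 10000 nM in this assay, at which 2 of the 2 values shown sit, the same place as compound 1, and no measured number separates them. Going by the values given here, the two differ in more than one part at once, so no single step can be drawn between them; their values show only that neither binds strongly.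

Compound 3, `C#CCN(C)C(=O)c1nc2ccccc2n1Cc1ccc(Cl)cc1`, has not yet been measured. It differs from compound 2 by chloro in place of methoxy on an aromatic carbon; cut one bond further out, the same change reads 4-methoxyphenyl to 4-chlorophenyl. Among the compounds with values here, compound 1 already carries the 4-chlorophenyl group and sits at the limit of > 10000 nM in this assay, at which 2 of the 2 values shown sit, so there is no measured step to draw on. Compound 2 gives > 10000 nM in this assay, a limit, and nothing pulls the expectation away from that. For compound 3 no step beyond the scatter is expected in this assay, in either direction. The step expected is a step that the limit leaves unreadable from compound 2 to compound 3. Compound 3 is expected to give 15000 nM, in the range 4000 nM to 60000 nM.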

Compound 3, inhibition constant: > 10000 nM
Compound 3: a limit, no number (the forecaster's own chance of this, stated with the estimate: 75%); the middle value is on the limit's open side.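

No step can be read from compound 2 to compound 3 or from compound 1 to compound 3, as all three compounds sit at a limit of the assay and not at a number: the limit of > 10000 nM in this assay, at which 3 of the 3 values shown sit.

The compounds shown leave open how weakly each one binds, and whether chloro in place of methoxy on an aromatic carbon changes binding at all.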